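A Dimethylamino Phenyl Swap on a Clean Cytotoxicity Background

The source may report more compounds than this note shows. Statements on the series, on what has been measured and on what is new or still open speak of the compounds shown alone.

Compound 1 `COc1ccc([C@H]2CC(=O)N(Cc3cccc(N)c3)C2)cc1OC1CCCC1` was tested in a functional assay on HEK293 cells (Homo sapiens) for cytotoxicity; on this read-out lower numbers stand for higher toxicity in this test and higher numbers for lower toxicity in this test. In this assay compound 1 reaches only the assay limit, recorded as > 10000 nM. Compound 2 `COc1ccc([C@H]2CC(=O)N(C(=O)c3ccccc3)C2)cc1OC1CCCC1` likewise reaches only the limit, with > 10000 nM. Compound 3 `COc1ccc([C@H]2CC(=O)N(c3cccc(O)c3)C2)cc1OC1CCCC1` also stops at the limit, giving > 10000 nM. The steps between them, a step that the two limits leave unreadable from compound 1 to compound 2, a step that the two limits leave unreadable from compound 1 to compound 3 and a step that the two limits leave unreadable from compound 2 to compound 3, therefore cannot be sized; what the three share is the limit of > 10000 nM in this assay, at which 3 of the 3 values shown sit.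

Compound 4 `COc1ccc([C@H]2CC(=O)N(c3cccc(N(C)C)c3)C2)cc1OC1CCCC1` differs from compound 1 as follows: 3-(dimethylamino)phenyl in place of 3-aminobenzyl on an amide-type nitrogen in a ring. The change replaces one group on the same ring nitrogen, as the measured steps do, and none of those steps produced a readable toxicity. No size or direction of step in this assay can be read from them, so no movement beyond the scatter is expected.

On that basis compound 4 is expected to sit near the limit, estimated at 15000 nM with a range from 5000 nM to 50000 nM. The step this estimate implies is a step that the limit leaves unreadable from compound 1 to compound 4, which is expected to be no real change.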

Compound 4, half-maximal cytotoxic concentration: > 10000 nM
Compound 4: a limit, no number; the forecaster's own chance of this, stated with the estimate: 80%; the middle value is on the limit's open side.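

Compound 4 also stops at a limit, so no step to compound 4 from compound 1, compound 2 or compound 3 can be read in this assay: the limit of > 10000 nM in this assay, at which 4 of the 4 values shown sit.

The compounds shown leave open whether any group on the ring nitrogen changes toxicity in this test at all.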